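The source may hold more compounds than are shown below. What is called first, only, known or untested is meant among the compounds shown, and "the series" means these compounds.

Measured so far:
- compound 1 `COc1ccc2[nH]c3c(c2c1)CCNC31CCN(Cc2ccc(Br)cc2F)CC1`; in an assay on FRT cells for positive allosteric modulation of Cystic fibrosis transmembrane conductance regulator variant N1303K (Homo sapiens), in the presence of a further agent that is not named here (on this read-out higher numbers stand for an effect only at larger amounts of compound and lower numbers for an effect already at smaller amounts), compound 1 gives 1600 nM
- compound 2 `COc1ccc2[nH]c3c(c2c1)CCNC31CCN(Cc2cc(F)ccc2F)CC1`; in this assay compound 2 gives 11100 nM

Compound 2 stands highest of the two numbers recorded. Going by the values given here, its nearest neighbour is compound 1, and the only measured step in the set is a 6.9-fold higher number from compound 1 to compound 2 (0.84 log units; beyond the scatter), a modest step beyond the scatter.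

Compound 3 `COc1ccc2[nH]c3c(c2c1)CCNC31CCN(Cc2cccc(F)c2F)CC1` is the next member. It differs from compound 2 by 2,3-difluorophenyl in place of 2,5-difluorophenyl on a saturated chain carbon bound to an amine nitrogen in a ring; the two compounds hold the same atoms, joined differently. Among the compounds with values here, the one measured step, a 6.9-fold higher number from compound 1 to compound 2 (0.84 log units; beyond the scatter), exchanges a bromine for a fluorine as well as rearranging the substituents, so it bears only loosely on a change that merely shifts a fluorine around the ring. Within the data shown here, there is no measured pair in which a fluorine alone is moved. The expectation is therefore a step of no more than the usual scatter, in either direction, summarised as a 1.2-fold lower number from compound 2 to compound 3 (0.09 log units; within the scatter).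

Compound 3 is estimated at 9000 nM, with a range from 3000 nM to 30000 nM.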

Compound 3, half-maximal effective concentration: 13600 nM
Compound 3: the middle estimate sits 1.5-fold (0.18 log units) below what was measured; low and high end bracket the measured number.
By their numbers in this assay, from the lowest: compound 1; then compounds 2 and 3 (each within the scatter of the next).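

In this assay, the change from 2,5-difluorophenyl to 2,3-difluorophenyl gives a 1.2-fold higher number from compound 2 to compound 3 (0.09 log units; within the scatter), so these two fluorine patterns are not separated at this position. The 4-bromo-2-fluorophenyl group of compound 1 stands apart from both difluorophenyl groups, with an 8.5-fold higher number from compound 1 to compound 3 (0.93 log units; beyond the scatter) alongside the earlier 6.9-fold higher number from compound 1 to compound 2 (0.84 log units; beyond the scatter). Nothing available here explains either the gap or the lack of one.

Compound 1 differs from compound 2 and compound 3 both in carrying bromine and in its overall substitution of the phenyl ring, so the compounds shown do not tell whether the bromine alone accounts for the gap. Also open, from the compounds shown here alone, is how this assay would read a phenyl ring carrying chlorine, a nitrile or an amine at this position.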